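A Biaryl Group in Place of an Ethynyl Group

The compounds below may be only part of what the source reports. "The series", "measured", "known", "first", "only" and "open" are said of these compounds alone.

Three amides built on a shared core were measured in a functional assay on MDA-MB-231 cells (Homo sapiens) for antiproliferative activity, read by MTT assay, with a stated time of 72 h; on this read-out lower numbers stand for stronger inhibition and higher numbers for weaker inhibition. Compound 1 `C#Cc1cccc(NC(=O)CCc2cccc3c2B(O)OC3)c1` gives 1600 nM in this assay. Compound 2 `COc1ccccc1NC(=O)CCc1cccc2c1B(O)OC2` gives 930 nM in this assay, a number that lies within the scatter of compound 1. Compound 3 `Cc1cc(C)c(NC(=O)CCc2cccc3c2B(O)OC3)c(C)c1` gives 71000 nM in this assay, a number beyond the scatter above compound 1. Compound 1 therefore stands second highest of the three, nearest compound 2 and furthest from compound 3. Compound 4 `CSc1cccc(-c2cccc(NC(=O)CCc3cccc4c3B(O)OC4)c2)c1` has not been measured; it differs from compound 1 by 3-(methylsulfanyl)phenyl in place of ethynyl on an aromatic carbon. Going by the values given here, no single-change step between measured compounds anchors this move, so the step of a 1.2-fold lower number from compound 1 to compound 4 (0.09 log units; within the scatter) is expected to stay within the scatter, with no clear direction. Compound 4 is estimated at 1300 nM in this assay, within a range from 300 nM to 6000 nM.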

Compound 4, half-maximal inhibitory concentration: 150 nM
For compound 4 the middle estimate is 8.7-fold (0.94 log units) above the measured one; measured number outside the range, below it.
By their numbers in this assay, from the lowest: compound 4; then compounds 2 and 1 (each within the scatter of the next); then compound 3.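

In this assay, the aromatic carbon that carries ethynyl in compound 1 also accepts a much larger group: 3-(methylsulfanyl)phenyl in its place gives an 11-fold lower number from compound 1 to compound 4 (1.03 log units; beyond the scatter) and brings in a six-membered aromatic ring where no ring stood. This is the only single-change step among the compounds shown, and it shows that a change at this position alone can move the number well beyond the scatter. No measurement at hand gives a reason for this step. Going by these compounds, it remains open whether the phenyl ring alone accounts for the step or whether the methylsulfanyl group contributes, and how a plain phenyl or a phenyl bearing an amine or a carboxylic acid would compare.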